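The source may report more compounds than this note shows. Statements on the series, on what has been measured and on what is new or still open speak of the compounds shown alone.

Compound 1 `C=CCn1c(=O)/c(=C\c2cc(F)ccc2C)[nH]c(=O)/c1=C\c1ccccc1OC` — in a functional assay on MCF7 cells (Homo sapiens) for cytotoxicity, read by CCK-8 assay, with a stated time of 72 h (on this read-out higher numbers stand for weaker inhibition and lower numbers for stronger inhibition), compound 1 gives 3100 nM.
Compound 2 `C=CCn1c(=O)/c(=C\c2cc(OC)c(OC)c(OC)c2)[nH]c(=O)/c1=C\c1cccc(Br)c1` — in this assay compound 2 is recorded as "not active" (no number reported), without a number.

Going by the values given here, compound 1 is the only compound of the pair with a numerical value in this assay; compound 2 has no number beside it, so no step between the two can be measured, and nothing can be said about their order. Compound 1 therefore stands alone as the reference point.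

Compound 3 `C=CCn1c(=O)/c(=C\c2ccc(Cl)c(Cl)c2)[nH]c(=O)/c1=C\c1ccccc1OC` has not yet been tested. It differs from compound 1 in one place: 3,4-dichlorophenyl in place of 5-fluoro-2-methylphenyl on a double-bonded chain carbon bound to an aromatic carbon. Among the compounds with values here, no pair of measured compounds shows what such a change does in this assay, so there is no measured step to lean on. With only the value of compound 1 to go by, the step from compound 1 to compound 3 is expected to be small, possibly none beyond the scatter, in either direction; the estimate is a 1.0-fold lower number from compound 1 to compound 3 (0.01 log units; within the scatter). On that basis compound 3 is expected to give about 3000 nM in this assay, with a likely range from 900 nM to 10000 nM.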

Compound 3, half-maximal inhibitory concentration: "not active" (no number reported)
Compound 3: no number reported; there is nothing to compare the estimate with.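

Going by these compounds alone, compound 3, like compound 2, is recorded in this assay without a number, so no step from compound 1 to compound 3 can be read from this result. No measured evidence on the cause is available here. The compounds shown leave open what replacing 5-fluoro-2-methylphenyl with 3,4-dichlorophenyl does to the number in this read-out.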